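Hydroxy-ethyl side chain on the isoxazole core of the series

A few compounds are considered here, and "the series" means these few. Any claim that something is new, unique, unknown or untested is made for them only; others in the source may bear on it.

Compound 1 `COc1cccc(Sc2c(NS(=O)(=O)c3ccc(C(C)(C)C)cc3)noc2CCCC(=O)O)c1` is the parent of this short series. For the measured compounds named here, in an assay on COS-7 cells for displacement of a labelled ligand from Endothelin receptor type B (Sus scrofa) (on this read-out lower numbers stand for stronger inhibition and higher numbers for weaker inhibition), compound 1 gives 500 nM, the highest of the two numbers measured so far. Its nearest neighbour is compound 2 `COc1cccc(Sc2c(NS(=O)(=O)c3ccc(C(C)(C)C)cc3)noc2C)c1`, which in this assay gives 300 nM; the step of a 1.7-fold lower number from compound 1 to compound 2 (0.22 log units; within the scatter) shows that removing the whole acid-bearing chain leaves the read-out essentially unchanged.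

Compound 3 `COc1cccc(Sc2c(NS(=O)(=O)c3ccc(C(C)(C)C)cc3)noc2CCO)c1` has not yet been measured. It differs from compound 1 by hydroxy in place of carboxymethyl on a saturated chain carbon, two bonds along the chain from an aromatic carbon, so the chain is shortened and the acid is replaced by an alcohol while a hydrogen-bond donor and acceptor are retained at the chain end. Going by the values given here, the only step that bears on this change is the one from compound 1 to compound 2, and it lies within the scatter, which gives no reason to expect a large shift in either direction from trimming the chain further.

For compound 3 the expected value in this assay is therefore 400 nM, with a likely range of 150 nM to 1200 nM, corresponding to an expected step of a 1.3-fold lower number from compound 1 to compound 3 (0.10 log units; within the scatter).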

Compound 3, half-maximal inhibitory concentration: 430 nM
Beside the measured number, compound 3's estimate is 1.1-fold (0.03 log units) below it, within the range that was stated.
By their numbers in this assay, from the lowest: compounds 2, 3 and 1 (each within the scatter of the next).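

In this assay, replacing the 3-carboxypropyl chain with 2-hydroxyethyl gives a 1.2-fold lower number from compound 1 to compound 3 (0.07 log units; within the scatter), so the carboxylic acid at the chain end is not required to keep the number at this level, even with a chain of intermediate form still in place. Extending the other way, hydroxymethyl in place of hydrogen on a saturated chain carbon bound to an aromatic carbon gives a 1.4-fold higher number from compound 2 to compound 3 (0.16 log units; within the scatter), which shows that a hydroxy-bearing chain reads the same, within the scatter, as the bare methyl end. Earlier only the loss of the whole chain could be read, whereas these three compounds now show no step beyond the scatter among a methyl, a 2-hydroxyethyl and a 3-carboxypropyl group at this position, and nothing on hand bears on why the number holds.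

Whether any group here can move the number beyond the scatter remains open, since an amine, an amide or a methyl ether at the chain end, or a longer chain carrying the hydroxy, lies outside the compounds shown. Also open, on these data alone, is whether this flat reading holds once other parts of the shared core are changed.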